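The source may report more compounds than this note shows. Statements on the series, on what has been measured and on what is new or still open speak of the compounds shown alone.

Working notes on the series in a functional assay on PC-3 cells (Homo sapiens) for cytotoxicity, read by MTT assay, with a stated time of 72 h; on this read-out lower numbers stand for stronger inhibition and higher numbers for weaker inhibition. Compound 1 `Cc1ccc(S(=O)(=O)n2cc(COC3=C/C(=N\c4ccccc4)c4ccccc4C3=O)nn2)cc1` reports only a limit, > 20000 nM. Compound 2 `Cc1ccc(S(=O)(=O)n2cc(COC3=C/C(=N\c4ccc(Br)cc4)c4ccccc4C3=O)nn2)cc1` gives 3410 nM, and compound 3 `Cc1ccc(/N=C2\C=C(OCc3cn(S(=O)(=O)c4ccc(C)cc4)nn3)C(=O)c3ccccc32)cc1` gives 2650 nM. These two numbers are the only ones not limited, and they sit together, with a 1.3-fold lower number from compound 2 to compound 3 (0.11 log units; within the scatter).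

The next compound to read is compound 4 `Cc1ccc(S(=O)(=O)n2cc(COC3=C/C(=N\c4ccc(Cl)cc4)c4ccccc4C3=O)nn2)cc1`, where the change is chloro in place of bromo on an aromatic carbon, para to a large group. Among the compounds with values here, three measured steps bear on it. Bromo in place of hydrogen gave an at least 5.8-fold lower number from compound 1 to compound 2 (0.76 log units; beyond the scatter), and methyl in place of hydrogen gave an at least 7.5-fold lower number from compound 1 to compound 3 (0.87 log units; beyond the scatter), so both substituents tested at this place stand clear of the limit. Within the data shown here, the closest precedent is methyl in place of bromo, which gave a 1.3-fold lower number from compound 2 to compound 3 (0.11 log units; within the scatter). A swap of one substituent for another therefore has so far moved little, and no change beyond the scatter is expected here. The expected size of the change is a 1.1-fold lower number from compound 2 to compound 4 (0.06 log units; within the scatter). Compound 4 is estimated at 3000 nM, with an expected range of 1300 nM to 7000 nM.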

Compound 4, half-maximal inhibitory concentration: > 20000 nM
Compound 4 ended at the assay's limit; the forecaster's own chance of this, stated with the estimate: 5%; at least 6.6-fold (0.82 log units) between middle value and limit.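

In this assay the change from 4-bromophenyl to 4-chlorophenyl is not the small swap that the earlier pair suggested: it gives an at least 5.8-fold higher number from compound 2 to compound 4 (0.76 log units; beyond the scatter), whereas methyl in place of bromo stayed within the scatter. Chloro in place of methyl reads the same way, with an at least 7.5-fold higher number from compound 3 to compound 4 (0.87 log units; beyond the scatter), so at this place, para to a large group, the identity of the substituent counts and not merely the presence of one: chloro joins hydrogen at the limit, while bromo and methyl give numbers. The step from compound 1 to compound 4 cannot be read, as both values are limits: the limit of > 20000 nM in this assay, at which 2 of the 4 values shown sit.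

No order can be given between compound 1 and compound 4. Going by these compounds, whether a methoxy group, an amine or a carboxylic acid at this place would stand with bromo and methyl or with chloro and hydrogen remains open.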